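Expected weaker sigma binding on enlarging the acetamide

A few compounds are considered here, and "the series" means these few. Any claim that something is new, unique, unknown or untested is made for them only; others in the source may bear on it.

Compound 1, `CC(=O)OC(CCCN1CCN(c2ncc(F)cn2)CC1)c1ccc(F)cc1`, gives 227 nM in an assay (Cavia porcellus) for displacement of a labelled ligand from Sigma non-opioid intracellular receptor 1 (Homo sapiens); a lower number here means a stronger inhibitor, a higher number a weaker inhibitor.
Compound 2, `O=C(OC(CCCN1CCN(c2ncc(F)cn2)CC1)c1ccc(F)cc1)c1ccccc1`, gives 3500 nM.
Compound 3, `CC(=O)NC(CCCN1CCN(c2ncc(F)cn2)CC1)c1ccc(F)cc1`, gives only a limit of the assay, > 49 nM.

Compound 3 therefore stands at the limit of > 49 nM in this assay, at which 1 of the 3 values shown sits, and its exact place among the measured numbers is not known. The steps a step that the limit leaves unreadable from compound 1 to compound 3 and a step that the limit leaves unreadable from compound 2 to compound 3 cannot be read for that reason.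

Compound 4, `O=C(NC(CCCN1CCN(c2ncc(F)cn2)CC1)c1ccc(F)cc1)c1ccc(F)cc1`, differs from compound 3 by a single change: 4-fluorophenyl in place of methyl on a carbonyl carbon. For the measured compounds named here, the one measured step of the same kind is a 15-fold higher number from compound 1 to compound 2 (1.19 log units; beyond the scatter), in which phenyl took the place of methyl on a carbonyl carbon and the number rose clearly beyond the scatter. Resting on that step alone, a rise of similar size is expected here, so that the estimate means a step that the limit leaves unreadable from compound 3 to compound 4 in this assay. Compound 4 is thus expected to give about 2000 nM, with a likely range from 300 nM to 15000 nM.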

Compound 4, half-maximal inhibitory concentration: > 100 nM
Compound 4: only a limit was reported (the forecaster's own chance of this, stated with the estimate: 30%); the middle value does not contradict the limit.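

In this assay compound 4 gives only a limit (> 100 nM), so none of its steps to compound 1, compound 2 or compound 3 can be read. Still open, going by these compounds, is where compound 3 and compound 4 truly stand, and whether 4-fluorophenyl in place of methyl raises the number at all.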